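From benzyl to 4-fluorobenzyl: working notes

The source may hold more compounds than are shown below. What is called first, only, known or untested is meant among the compounds shown, and "the series" means these compounds.

In a functional assay, read by spectrophotometry, with a stated time of 30 min (on this read-out lower numbers stand for stronger inhibition and higher numbers for weaker inhibition), compound 1 (`CC(C)(C)c1cc(CCC(=O)NC2CCN(Cc3ccccc3)CC2)cc(C(C)(C)C)c1O`) gives 80300 nM and compound 2 (`CC(C)(C)c1cc(/C=C/C(=O)NCCC2CCN(Cc3ccccc3)CC2)cc(C(C)(C)C)c1O`) gives 81700 nM with the two numbers within the scatter of each other. Within the data shown here, compound 3 (`CC(C)(C)c1cc(/C=C/C(=O)NCCC2CCN(Cc3ccc(F)cc3)CC2)cc(C(C)(C)C)c1O`) differs from compound 2 by fluoro in place of hydrogen on an aromatic carbon and no measured pair tests this change. No step beyond the scatter is expected in this assay for this change. The expected move is a 1.3-fold lower number from compound 2 to compound 3 (0.10 log units; within the scatter) and it stays inside the scatter. For compound 3 the estimated value is 65000 nM with 25000 nM to 130000 nM as the expected range.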

Compound 3, half-maximal inhibitory concentration: 57500 nM
For compound 3 the middle estimate is 1.1-fold (0.05 log units) above the measured one; the measured number falls inside the stated range.
By their numbers in this assay, from the lowest: compounds 3, 1 and 2 (each within the scatter of the next).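

Benzyl to 4-fluorobenzyl is the first single-place change that can be read in this series, and in this assay it gives a 1.4-fold lower number from compound 2 to compound 3 (0.15 log units; within the scatter) so fluoro on this aromatic carbon, para to a large group, produces no step beyond the scatter. Nothing available on the series bears on this result.

Still open, going by these compounds, is whether chloro, methoxy or an amine on the same aromatic carbon would move the number beyond the scatter. Also open, on these data alone, is whether fluoro in place of hydrogen at this position gives a similar step on compound 1.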